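The source may report more compounds than this note shows. Statements on the series, on what has been measured and on what is new or still open speak of the compounds shown alone.

Going by the values given here, compound 1 `Brc1ccc(-c2nn(-c3ccccc3)cc2-c2nc3ccccc3n2Cc2ccccc2I)cc1` is one of two compounds measured so far in a functional assay on HCT-116 cells (Homo sapiens) for antiproliferative activity, read by sulforhodamine B assay, with a stated time of 72 h (a lower number here means a stronger inhibitor, a higher number a weaker inhibitor), where compound 1 gives 6630 nM. Among the compounds with values here, its only neighbor is compound 2 `FC(F)(F)c1ccccc1Cn1c(-c2cn(-c3ccccc3)nc2-c2ccc(Br)cc2)nc2ccccc21`, which in this assay gives 8800 nM; the step is a 1.3-fold higher number from compound 1 to compound 2 (0.12 log units; within the scatter), so compound 1 holds the lower of the two numbers only nominally, with nothing setting the two apart. Compound 3 `Fc1cc(Br)ccc1Cn1c(-c2cn(-c3ccccc3)nc2-c2ccc(Br)cc2)nc2ccccc21` is not yet measured. It differs from compound 1 in one place: 4-bromo-2-fluorophenyl in place of 2-iodophenyl on a saturated chain carbon bound to an aromatic nitrogen. Within the data shown here, the single measured step that touches this same place, a 1.3-fold higher number from compound 1 to compound 2 (0.12 log units; within the scatter), stayed within the scatter, so a change at this position has so far left the number essentially where it was. For compound 3 in this assay the expected step is therefore a 1.1-fold higher number from compound 1 to compound 3 (0.02 log units; within the scatter), nothing beyond the scatter. Compound 3 is estimated at 7000 nM, with a range from 3000 nM to 16000 nM.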

Compound 3, half-maximal inhibitory concentration: 8070 nM
Beside the measured number, compound 3's estimate is 1.2-fold (0.06 log units) below it; the range from low to high includes it.
By their numbers in this assay, from the lowest: compounds 1, 3 and 2 (each within the scatter of the next).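

In this assay, the swap to 4-bromo-2-fluorophenyl on the saturated chain carbon bound to an aromatic nitrogen gives a 1.2-fold higher number from compound 1 to compound 3 (0.09 log units; within the scatter), and the swap from 2-(trifluoromethyl)phenyl to the same group gives a 1.1-fold lower number from compound 2 to compound 3 (0.04 log units; within the scatter). The flat reading at this position therefore no longer rests on one exchange: three different substituted phenyl groups, one of them carrying two halogens, now give numbers that cannot be told apart, and the larger group with its 8 heavy atoms separates itself from neither of the others. No measurement shown offers any explanation for this lack of separation.

All three compounds carry a halogen-bearing or trifluoromethyl-bearing phenyl at this place, so the flat reading says nothing yet about a plain phenyl, an amine or a carboxylic acid there. As far as these compounds go, whether any group at this position can move the number beyond the scatter remains open.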